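A few compounds are considered here, and "the series" means these few. Any claim that something is new, unique, unknown or untested is made for them only; others in the source may bear on it.

Compound 1 `CS(=O)(=O)N(CC1CC1)c1ccccc1N1CCN(C(=O)[C@H](CC(=O)N2CCNCC2)Cc2ccc(Cl)cc2)CC1` gives 2000 nM in a functional assay with Melanocortin receptor 4 (Homo sapiens) as the target, read by cAMP accumulation; on this read-out lower numbers stand for an effect already at smaller amounts and higher numbers for an effect only at larger amounts of compound. Compound 2 `CC(C)CCN1CCN(C(=O)C[C@H](Cc2ccc(Cl)cc2)C(=O)N2CCN(c3ccccc3N(CC3CC3)S(C)(=O)=O)CC2)CC1` carries an isopentyl group on the amine nitrogen of the terminal ring where compound 1 has only a hydrogen. For compound 2 this assay reports only a limit, > 10000 nM, not a number. The step of an at least 5.0-fold higher number from compound 1 to compound 2 (0.69 log units; beyond the scatter) therefore points to a loss of potency, and its exact size is hidden because the limit of > 10000 nM in this assay, at which 1 of the 2 values shown sits, caps what can be read.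

Compound 3 `CS(=O)(=O)N(CC1CC1)c1ccccc1N1CCN(C(=O)[C@H](CC(=O)N2CCN(CC3CC3)CC2)Cc2ccc(Cl)cc2)CC1` differs from compound 2 by cyclopropyl in place of isobutyl on a saturated chain carbon bound to an amine nitrogen in a ring: the amine nitrogen stays substituted, only the chain that hangs from it changes shape. For the measured compounds named here, the one measured step, from compound 1 to compound 2, concerns the presence of a substituent on that nitrogen rather than its shape, so it bears on compound 3 only indirectly. Since compound 3 keeps a substituent there, the expectation for it is a step that the limit leaves unreadable from compound 2 to compound 3 that stays within the scatter, with the starting point itself known only as a limit. Compound 3 is accordingly estimated at 15000 nM, within a range from 4000 nM to 50000 nM.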

Compound 3, half-maximal effective concentration: > 10000 nM
Compound 3 gave a limit, no number (the forecaster's own chance of this, stated with the estimate: 60%); the middle value does not contradict the limit.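

In this assay compound 3 gives > 10000 nM as a limit, not a number. Putting cyclopropylmethyl in place of the hydrogen on the amine nitrogen in the ring gives an at least 5.0-fold higher number from compound 1 to compound 3 (0.69 log units; beyond the scatter) as a step, so the loss of potency seen with isopentyl is not tied to that one chain: two differently shaped groups at this nitrogen, one of them carrying a three-membered ring, both go with a weaker effect than the free amine of compound 1. Whether isopentyl and cyclopropylmethyl differ from each other cannot be read, because both compounds reach the ceiling of what the assay shows: the limit of > 10000 nM in this assay, at which 2 of the 3 values shown sit.

The compounds shown leave open how much weaker compound 2 and compound 3 really are, since neither has a number of its own. They also leave open whether a smaller group on this nitrogen, such as methyl, or a group of another kind, such as acetyl or a short chain ending in a carboxylic acid, would stay close to compound 1 or fall away as these two do.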